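Furan for thiophene at the saturated ring carbon of compound 3

The compounds below may be only part of what the source reports. "The series", "measured", "known", "first", "only" and "open" are said of these compounds alone.

Of the compounds shown here, three on the shared core have been measured in a functional assay on PC-3 cells (Homo sapiens) for cytotoxicity, read by MTT assay, with a stated time of 48 h; a higher number here means a weaker inhibitor, a lower number a stronger inhibitor. Compound 1 `COc1ccc(C(=O)C2Sc3nnc(-c4cc(OC)c(OC)c(OC)c4)n3NC2c2ccco2)cc1` gives > 100000 nM, which is a limit, (the limit of > 100000 nM in this assay, at which 1 of the 3 values shown sits), and not a number. Compound 2 `COc1cc(-c2nnc3n2NC(c2ccco2)C(C(=O)c2cccc(Br)c2)S3)cc(OC)c1OC` gives 63900 nM; the step of an at least 1.5-fold lower number from compound 1 to compound 2 (0.19 log units; that floor lies within the scatter) rests on that limit. Compound 3 `COc1cc(-c2nnc3n2NC(c2cccs2)C(C(=O)c2ccc(Cl)cc2)S3)cc(OC)c1OC` gives 32500 nM, and its gap to compound 2 lies within the scatter, so no order between the two can be read.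

Compound 4 `COc1cc(-c2nnc3n2NC(c2ccco2)C(C(=O)c2ccc(Cl)cc2)S3)cc(OC)c1OC` differs from compound 3 by furan-2-yl in place of thiophen-2-yl on a saturated ring carbon. Going by the values given here, no measured step changes this group alone: compounds 1 and 2 carry furan-2-yl but differ from compound 3 in two places. Hence no step beyond the scatter is expected for a 1.1-fold higher number from compound 3 to compound 4 (0.03 log units; within the scatter), and compound 4 is estimated at 35000 nM, from 15000 nM to 90000 nM.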

Compound 4, half-maximal inhibitory concentration: 67800 nM
Compound 4: middle estimate off by 1.9-fold (0.29 log units), on the low side, within the range that was stated.
By their numbers in this assay, from the lowest: compounds 3, 2 and 4 (each within the scatter of the next, the first and the last beyond it). At a limit, above all of these: compound 1.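

In this assay the saturated ring carbon gives its first single-place step: a 2.1-fold higher number from compound 3 to compound 4 (0.32 log units; beyond the scatter) so furan-2-yl and thiophen-2-yl can be told apart here, though only modestly. With furan-2-yl in place, 4-chlorophenyl in place of 3-bromophenyl on a carbonyl carbon gives a 1.1-fold higher number from compound 2 to compound 4 (0.03 log units; within the scatter) so 4-chlorophenyl and 3-bromophenyl cannot be ordered. Chloro in place of methoxy on an aromatic carbon gives an at least 1.4-fold lower number from compound 1 to compound 4 (0.16 log units; that floor lies within the scatter) and this step cannot be read. Compound 1 stands at a limit: the limit of > 100000 nM in this assay, at which 1 of the 4 values shown sits.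

As far as these compounds go, the furan-2-yl for thiophen-2-yl step rests on one pair, so whether it holds with other groups on the carbonyl carbon stays open. Also open, from the compounds shown here alone, is how in this assay a phenyl ring or an amine on the saturated ring carbon would read.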